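The source may report more compounds than this note shows. Statements on the series, on what has been measured and on what is new or still open speak of the compounds shown alone.

In a functional assay on A549 cells (Homo sapiens) for cytotoxicity, read by MTT assay, with a stated time of 72 h (a higher number here means a weaker inhibitor, a lower number a stronger inhibitor), compound 3 `O=C(Nc1nnc(-c2ccc(O)c(O)c2)s1)C1CCCCC1` gives 16300 nM. This lies within the scatter of compound 1 `Cc1ccc(C(=O)Nc2nnc(-c3ccc(O)c(O)c3)s2)cc1` at 11800 nM and of compound 2 `O=C(Nc1nnc(-c2cccc(O)c2O)s1)c1ccccc1` at 12300 nM. Compound 4 `CC(=O)Nc1nnc(-c2ccc(O)c(O)c2)s1` differs from compound 3 in one place, with methyl in place of cyclohexyl on a carbonyl carbon. Going by the values given here, one measured step bears on this change: a 1.4-fold higher number from compound 1 to compound 3 (0.14 log units; within the scatter), with cyclohexyl in place of 4-methylphenyl at that same carbonyl carbon, stays within the scatter. Among the compounds with values here, no measured compound carries methyl there, so this evidence is indirect. No step beyond the scatter is therefore expected in this assay, and no direction can be favoured. Compound 4 is estimated at 18000 nM, with an expected range from 8000 nM to 45000 nM. This estimate means a 1.1-fold higher number from compound 3 to compound 4 (0.04 log units; within the scatter).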

Compound 4, half-maximal inhibitory concentration: 133000 nM
Compound 4: middle estimate off by 7.4-fold (0.87 log units), on the low side; the whole stated range lies below it.
By their numbers in this assay, from the lowest: compounds 1, 2 and 3 (each within the scatter of the next); then compound 4.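

Swapping cyclohexyl for 4-methylphenyl on the carbonyl carbon had stayed within the scatter, so the earlier compounds showed no sensitivity to the group there. Methyl changes that in this assay, with an 8.2-fold higher number from compound 3 to compound 4 (0.91 log units; beyond the scatter) and an 11-fold higher number from compound 1 to compound 4 (1.05 log units; beyond the scatter), so this position does respond to the group it carries, and the two larger groups both stand well apart from methyl. Nothing measured here gives a reason for this step. As far as these compounds go, whether a propyl chain or a cyclopropyl ring on that carbonyl carbon would side with methyl or with the larger groups remains open, as does the effect of an amine there.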